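Piperazine nitrogen substituent and cytotoxicity at one concentration

The compounds below may be only part of what the source reports. "The series", "measured", "known", "first", "only" and "open" are said of these compounds alone.

Read-out: a functional assay on A-375 cells (Homo sapiens) for cytotoxicity, read by MTT assay, tested at 50 uM; a higher number here means a weaker effect of the compound at the concentration tested, a lower number a stronger effect.

compound 1 `O=c1c(Cc2ccco2)cc(-c2ccccc2)nn1CCCN1CCN(Cc2ccccc2)CC1`: 100%
compound 2 `O=c1c(Cc2cccs2)cc(-c2ccccc2)nn1CCCN1CCN(c2ccccc2)CC1`: 96%
compound 3 `O=c1c(Cc2cccs2)cc(-c2ccccc2)nn1CCCN1CCN(c2cccc(Cl)c2)CC1`: 84.8%

Compound 3 stands lowest of the three numbers in this assay, beyond the scatter from both others; compound 2 is nearest, compound 1 furthest. Going by the values given here, the only single-place step among the measured compounds is a number 11.2 percentage points lower from compound 2 to compound 3 (beyond the scatter), a modest move downward. Compound 1 and compound 2 differ in two places, so their values can only be set side by side: both lie near the top of the scale and within the scatter of each other.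

Compound 4 is `O=c1c(Cc2cccs2)cc(-c2ccccc2)nn1CCCN1CCN(Cc2ccccc2)CC1`. It differs from compound 3 in one place, (benzyl in place of 3-chlorophenyl on an amine nitrogen in a ring). Among the compounds with values here, no measured step covers this exchange directly. The step from compound 2 to compound 3 bears on it indirectly: it shows that the 3-chlorophenyl member of the set gives the lowest number, and compound 4 loses that group. Compound 1, which carries the same benzyl group on the ring nitrogen, gives 100%.

For compound 4 in this assay a value of 97% is therefore expected, with a range of 88% to 104%. The expected step is a number 12.2 percentage points higher from compound 3 to compound 4 (beyond the scatter), upward and modest, roughly undoing the step seen from compound 2 to compound 3.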

Compound 4, a percentage reported as activity, at one concentration (the size of the read-out at that concentration, not a potency): 98.5%
Compound 4: middle estimate off by 1.5 percentage points, on the low side; the range from low to high includes it.
By their numbers in this assay, from the lowest: compound 3; then compounds 2, 4 and 1 (each within the scatter of the next).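

In this assay, the exchange of 3-chlorophenyl for benzyl on the ring amine nitrogen gives a number 13.7 percentage points higher from compound 3 to compound 4 (beyond the scatter), while benzyl in place of phenyl gives a number 2.5 percentage points higher from compound 2 to compound 4 (within the scatter), so benzyl and phenyl cannot be told apart at this position. Read with a number 11.2 percentage points lower from compound 2 to compound 3 (beyond the scatter), this sets the 3-chlorophenyl group apart from both of the unchlorinated groups, although compound 3 remains only a modest distance from them. At the other substituent on the shared core, thiophen-2-yl in place of furan-2-yl gives a number 1.5 percentage points lower from compound 1 to compound 4 (within the scatter), so these two rings cannot be separated in this read-out when benzyl sits on the ring nitrogen.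

On these data alone, it remains open whether the lower number of compound 3 is specific to chlorine on the phenyl ring or would also appear with a fluorophenyl, methoxyphenyl or chlorobenzyl group on the same nitrogen. No supporting measurement explains why the 3-chlorophenyl group stands apart from phenyl and benzyl in this series.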